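Anilino for Hydroxy on a Fused Four-Ring Core

The source may report more compounds than this note shows. Statements on the series, on what has been measured and on what is new or still open speak of the compounds shown alone.

Measured compounds:
compound 1, `C/C1=C/C2=C[C@H](C)C[C@@]23O[C@]2(CC(C)(C)[C@@H](O)[C@@H]2C1=O)[C@@H](C)C3=O`, 26000 nM
compound 2, `C/C1=C/C2=C[C@H](C)C[C@@]23O[C@]2(CC(C)(C)C4CC1(ON4)O2)C(C)C3=O`, 26000 nM

Of the compounds shown here, two sharing a fused core have been tested in an ADME assay on HEK293 cells (Homo sapiens) for cytotoxicity, read by CellTiter-Glo, with a stated time of 72 h; a lower number here means that less compound is needed, a higher number that more compound is needed for the effect. Compound 1 `C/C1=C/C2=C[C@H](C)C[C@@]23O[C@]2(CC(C)(C)[C@@H](O)[C@@H]2C1=O)[C@@H](C)C3=O` gives 26000 nM in this assay. Compound 2 `C/C1=C/C2=C[C@H](C)C[C@@]23O[C@]2(CC(C)(C)C4CC1(ON4)O2)C(C)C3=O` gives 26000 nM in this assay. The two values sit level at the digits shown, within the scatter of each other, so no order between compound 1 and compound 2 can be read from them, and nothing here tells how this assay answers a change at the hydroxy-bearing position.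

Compound 3 `C/C1=C/C2=C[C@H](C)C[C@@]23O[C@]2(CC(C)(C)[C@@H](Nc4ccccc4)[C@@H]2C1=O)[C@@H](C)C3=O` differs from compound 1 by one change: anilino in place of hydroxy on a saturated ring carbon. Within the data shown here, with no measured step to lean on, the change is read on its own. The expectation is that compound 3 stays in the same region as compound 1, with a step of a 1.4-fold lower number from compound 1 to compound 3 (0.16 log units; within the scatter) that is expected to be small and within the scatter, if anything toward a lower number. The estimate for compound 3 in this assay is 18000 nM, with a range from 6000 nM to 50000 nM.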

Compound 3, half-maximal effective concentration: 26000 nM
Estimate against measurement, compound 3: 1.4-fold (0.16 log units) below; the range from low to high includes it.
By their numbers in this assay, from the lowest: compounds 1, 2 and 3 (each within the scatter of the next).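

Anilino in place of hydroxy on a saturated ring carbon gives no change at the digits printed from compound 1 to compound 3 (within the scatter) in this assay, the first step read at this position. The change is not a small one in kind: a group with a six-membered aromatic ring of carbon only enters where a group with no ring stood, while the hydrogen-bond donor and acceptor counts stay the same and no net charge appears, and the number in this assay still does not move outside the scatter, so at this carbon, in this pair, the added ring leaves the reading level. Nothing at hand explains why this exchange leaves the value in place.

Going by these compounds, whether a primary amine, a carboxylic acid or a longer alkyl chain on the same carbon would also leave the number level stays open, as does the effect of a substituent on the aromatic ring of the anilino group. With only this one step read at the position, the compounds shown also leave open whether any change here can shift the number in this assay at all.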